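A few compounds are considered here, and "the series" means these few. Any claim that something is new, unique, unknown or untested is made for them only; others in the source may bear on it.

Compound 1, `CCOC(=O)C1=Cc2ccccc2OC1(OCc1cn(-c2cccc(OC)c2)nn1)C(F)(F)F`, was tested in a functional assay on DU-145 cells (Homo sapiens) for inhibition, read by MTT assay, with a stated time of 24 h; on this read-out lower numbers stand for stronger inhibition and higher numbers for weaker inhibition. In this assay compound 1 gives > 150000 nM, which is a limit of the assay rather than a number. Compound 2, `CCOC(=O)C1=Cc2ccccc2OC1(OCc1cc(-c2ccc(OC)cc2)no1)C(F)(F)F`, gives > 150000 nM in this assay, again a limit. Both measured values thus sit at the limit of > 150000 nM in this assay, at which 2 of the 2 values shown sit. Compound 3, `CCOC(=O)C1=Cc2ccccc2OC1(OCc1cn(CC(=O)Nc2ccc(I)cc2Cl)nn1)C(F)(F)F`, has not yet been measured; it differs from compound 1 by ((2-chloro-4-iodophenyl)carbamoyl)methyl in place of 3-methoxyphenyl on an aromatic nitrogen. Among the measured compounds shown here, no step between measured compounds is available for guidance. Only a small step is expected, an at least 1.5-fold lower number from compound 1 to compound 3 (0.17 log units; that floor lies within the scatter), and the result may again be a limit. Compound 3 is expected to give about 100000 nM, in a range from 20000 nM to 300000 nM.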

Compound 3, half-maximal inhibitory concentration: 24400 nM
The estimate for compound 3 lay 4.1-fold (0.61 log units) above the measured number; measured number inside the range.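

On the aromatic nitrogen of the five-membered ring, ((2-chloro-4-iodophenyl)carbamoyl)methyl in place of 3-methoxyphenyl yields a real number rather than a limit in this assay, with an at least 6.1-fold lower number from compound 1 to compound 3 (0.78 log units; beyond the scatter). This shows that a change at this position can move the read-out, which the earlier limits alone could not show. The full size of the step stays unknown because compound 1 gives only a limit: the limit of > 150000 nM in this assay, at which 2 of the 3 values shown sit.

The new group brings an amide, a chlorine and an iodine at once, and the compounds shown do not separate their contributions. As far as these compounds go, whether a simple benzyl group or an amine on this nitrogen would do the same also remains open.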